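The source may hold more compounds than are shown below. What is called first, only, known or untested is meant among the compounds shown, and "the series" means these compounds.

Compound 1, `CCCCCCC#Cc1ccc(S(=O)(=O)Nc2cccc(-c3csc(NC(C)=O)n3)c2)cc1`, is the stronger of the two measured compounds in a functional assay on A-375 cells (Homo sapiens) for antiproliferative activity, read by trypan blue exclusion, with a stated time of 48 h, tested at 10 uM; a higher number here means a weaker effect of the compound at the concentration tested, a lower number a stronger effect: compound 1 gives 5.8%, the lowest of the two numbers. Going by the values given here, its only measured neighbour is compound 2, `CC(=O)Nc1nc(-c2cccc(NS(=O)(=O)c3ccc(C#CCO)cc3)c2)cs1`, which in this assay gives 48.8%; the step of a number 43 percentage points higher from compound 1 to compound 2 (beyond the scatter) comes from a hydroxy in place of pentyl on the saturated chain carbon bound to the triple-bonded carbon. Compound 3, `CC(=O)Nc1nc(-c2cccc(NS(=O)(=O)c3ccc(C#CCCc4ccccc4)cc3)c2)cs1`, is not yet measured. It differs from compound 1 by phenyl in place of butyl on a saturated chain carbon, two bonds along the chain from a triple-bonded carbon. Among the compounds with values here, no measured step matches this change: the one step known swaps a chain for a hydroxy group that brings a hydrogen-bond donor and acceptor, whereas here a phenyl with no donors or acceptors enters for butyl. The large loss seen in the step to compound 2 therefore bears on it only loosely. Compound 3 is expected to stay near compound 1, with a step of a number 6.2 percentage points higher from compound 1 to compound 3 (within the scatter) that may lie within the scatter or rise slightly. The estimate for compound 3 in this assay is 12%, with a range from 3% to 35%.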

Compound 3, a percentage reported as activity, at one concentration (the size of the read-out at that concentration, not a potency): < 1%
Compound 3: only a limit was reported (the forecaster's own chance of this, stated with the estimate: 0%); middle value at least 11 percentage points from the limit.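

In this assay compound 3 is reported only as a limit: the limit of < 1% in this assay, at which 1 of the 3 values shown sits. Phenyl in place of butyl, on a saturated chain carbon two bonds along the chain from a triple-bonded carbon, gives a number at least 4.8 percentage points lower from compound 1 to compound 3 (that floor lies within the scatter), so at this position an aromatic ring in place of an open chain shows no loss of effect. Benzyl in place of hydroxy on the saturated chain carbon bound to a triple-bonded carbon gives a number at least 47.8 percentage points lower from compound 2 to compound 3 (beyond the scatter), so benzyl, like pentyl in compound 1, holds the effect that hydroxy in compound 2 does not.

Whether compound 3 truly goes beyond compound 1 cannot be read from this limit. The compounds shown also leave open how an amine, a carboxylic acid or a longer chain would fare in place of pentyl on this carbon.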